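The source may hold more compounds than are shown below. What is called first, only, known or untested is meant among the compounds shown, and "the series" means these compounds.

Working notes on the series. Going by the values given here, compound 2 `Nc1cccc(-c2cn3nc(-c4ccccc4)sc3n2)c1` is the one member with a number rather than a limit: in a functional assay on CCRF-CEM cells (Homo sapiens) for inhibition, read by cell counting, with a stated time of 3 days (a higher number here means a weaker inhibitor, a lower number a stronger inhibitor), compound 2 gives 33000 nM. Compound 1 `CCOc1ccc(-c2nn3cc(-c4cccc(N)c4)nc3s2)cc1`, which carries an ethoxy group on an aromatic carbon, reaches only the limit of this assay, so that compound 1 gives > 250000 nM. Among the compounds with values here, the single measured step, an at least 7.5-fold lower number from compound 1 to compound 2 (0.87 log units; beyond the scatter), runs from that limit to a number and is therefore known only as a lower bound, since its starting point sits at the limit of > 250000 nM in this assay, at which 1 of the 2 values shown sits.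

Compound 3 `Cc1ccc(-c2nn3cc(-c4cccc(N)c4)nc3s2)cc1` is not yet measured. It differs from compound 2 as follows: methyl in place of hydrogen on an aromatic carbon. The measured step bears on this directly, as it concerns the same aromatic carbon: an ethoxy group there gave at least a modestly higher number than hydrogen. A methyl group entering the same place is expected to move the number in the same direction, by a step of roughly this size or somewhat smaller, a 2.4-fold higher number from compound 2 to compound 3 (0.38 log units; beyond the scatter). Compound 3 is thus estimated at 80000 nM, within a range of 25000 nM to 250000 nM, with a fair chance that this assay again reports only a limit.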

Compound 3, half-maximal inhibitory concentration: 5900 nM
Estimate against measurement, compound 3: 14-fold (1.13 log units) above, and the stated range ends above it.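

The aromatic carbon para to a large group does not respond in one direction in this assay: methyl in place of hydrogen gives a 5.6-fold lower number from compound 2 to compound 3 (0.75 log units; beyond the scatter), whereas hydrogen in place of ethoxy gave an at least 7.5-fold lower number from compound 1 to compound 2 (0.87 log units; beyond the scatter), so a group at this place can lower the number as well as raise it. The outcome therefore depends on which group enters and not merely on whether the place is filled, as methyl in place of ethoxy gives an at least 42-fold lower number from compound 1 to compound 3 (1.62 log units; beyond the scatter), the widest step in the series and one known only as a lower bound. Compound 1 stands at a limit of the assay and has no number, so that step has no upper end: the limit of > 250000 nM in this assay, at which 1 of the 3 values shown sits.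

Going by these compounds, with only hydrogen, methyl and ethoxy at this place, it remains open whether the lower number belongs to methyl alone or extends to ethyl, to chlorine or to an amine. On these data alone, all three compounds share the core and its aminophenyl group, so the response to a carboxylic acid in place of that amine also remains open.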